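Ring ether in place of the butoxyethyl chain

The source may report more compounds than this note shows. Statements on the series, on what has been measured and on what is new or still open speak of the compounds shown alone.

Of the compounds shown here, three on a shared core have been measured in an assay on HEK293 cells for agonist activity at transient receptor potential cation channel subfamily M member 8 (Homo sapiens), read by fluorescence and calcium flux, with a stated time of 5 min; on this read-out lower numbers stand for an effect already at smaller amounts and higher numbers for an effect only at larger amounts of compound. Compound 1 `C=CCc1cc(OC)c(O[C@H](C)[C@@H](OCC)c2ccc(O)c(OC)c2)c(OC)c1` gives 1150 nM, compound 3 `C=CCc1cc(OC)c(O[C@H](C)[C@H](OCC)c2ccc(O)c(OC)c2)c(OC)c1` gives 583 nM, and compound 2 `C=CCc1cc(OC)c(OC(C)C(OCCOCCCC)c2ccc(O)c(OC)c2)c(OC)c1` gives 153 nM, the lowest of the three and beyond the scatter from both others. For the measured compounds named here, the one measured step, a 2.0-fold lower number from compound 1 to compound 3 (0.30 log units; within the scatter), concerns the fact that compounds 1 and 3 differ only in the configuration as drawn and leaves the ether untouched. Compound 4 `C=CCc1cc(OC)c(OC(C)C(O[C@H]2C[C@@H](C)CC[C@@H]2C(C)C)c2ccc(O)c(OC)c2)c(OC)c1` differs from compound 2 by a group of 10 heavy atoms (10 carbon; one six-membered non-aromatic ring of carbon only) in place of a group of 7 heavy atoms (6 carbon, 1 oxygen; no ring), on an oxygen on a saturated carbon. Going by the values given here, no measured step bears directly on this change; the values of compound 1 and compound 3 beside compound 2 show only that the longer ether carried the lower number. Compound 4 is therefore expected near 90 nM, within 20 nM to 400 nM. This expected step, a 1.7-fold lower number from compound 2 to compound 4 (0.23 log units; within the scatter), is modest in this assay.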

Compound 4, half-maximal effective concentration: 11 nM
The estimate for compound 4 lay 8.2-fold (0.91 log units) above the measured number, outside the stated range (below it).
By their numbers in this assay, from the lowest: compound 4; then compound 2; then compounds 3 and 1 (each within the scatter of the next).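

In this assay the change on this oxygen gives a 14-fold lower number from compound 2 to compound 4 (1.14 log units; beyond the scatter), so at this place a six-membered ring of carbon only carries a far lower number than the 2-butoxyethyl chain. For the compounds shown here, the one earlier step concerned configuration alone, and this is the only direct reading of the group on this oxygen. Nothing at hand accounts for the size of this step.

The compounds shown leave open what the defined stereocentres of the entering group contribute. They also leave open whether a plain cyclohexyl group or a piperidine ring would give a comparable number.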